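Triazole-thioether amides against the IL15 receptor

A few compounds are considered here, and "the series" means these few. Any claim that something is new, unique, unknown or untested is made for them only; others in the source may bear on it.

Measured so far:
compound 1 `Cn1c(Cc2nn(C)c(=O)c3ccccc23)nnc1SCCCC(=O)Nc1ccc(Cl)cc1Cl` — 9800 nM
compound 2 `Cn1c(Cc2nn(C)c(=O)c3ccccc23)nnc1SCCCCCC(=O)Nc1ccc(Cl)cc1Cl` — 4100 nM
compound 3 `CN(C(=O)CSc1nnc(Cc2nn(C)c(=O)c3ccccc23)n1C)c1ccc(Cl)cc1Cl` — > 30000 nM

In an assay on isolated protein (Mus musculus) for inhibition of IL15-IL15 receptor (Homo sapiens), read by resazurin assay, with stated times of 30 min and 2.5 days (on this read-out lower numbers stand for stronger inhibition and higher numbers for weaker inhibition), compound 1 gives 9800 nM and compound 2 gives 4100 nM. Among the measured compounds shown here, for compound 3 this assay reports only a limit, > 30000 nM, so no number places it beside the other two; it stands at the limit of > 30000 nM in this assay, at which 1 of the 3 values shown sits, and is the one member of the set without a measured value.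

Compound 4 `Cn1c(Cc2nn(C)c(=O)c3ccccc23)nnc1SCC(=O)Nc1ccc(Br)cc1Br` differs from compound 3 in one place: (2,4-dibromophenyl)amino in place of (2,4-dichlorophenyl)(methyl)amino on a carbonyl carbon. The entering group carries the hydrogen-bond donor that the leaving group lacks, and the halogens change as stated. For the measured compounds named here, no step between measured compounds covers this change, so its direction rests on the values of compounds 1 and 2, which both sit at measurable numbers with an unsubstituted amide nitrogen. A step from the limit toward a measurable number is expected, of moderate size, as an at least 2.0-fold lower number from compound 3 to compound 4 (0.30 log units; that floor lies within the scatter). Compound 4 is estimated at 15000 nM, with a range from 5000 nM to 40000 nM.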

Compound 4, half-maximal inhibitory concentration: > 30000 nM
Compound 4: a limit, no number (the forecaster's own chance of this, stated with the estimate: 35%); middle value at least 2.0-fold (0.30 log units) away from the limit.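

No step can be read from compound 3 to compound 4, since each stands only at a limit of the assay: the limit of > 30000 nM in this assay, at which 2 of the 4 values shown sit.

The compounds shown leave open how the amide hydrogen and the change of halogen would each count on their own.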